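Replacing the cyclobutyl group of compound 3

The compounds below may be only part of what the source reports. "The series", "measured", "known", "first", "only" and "open" are said of these compounds alone.

Values in a functional assay on PC-3 cells (Homo sapiens) for inhibition, read by sulforhodamine B assay, with a stated time of 72 h (on this read-out higher numbers stand for weaker inhibition and lower numbers for stronger inhibition), are:
- compound 1 `Nc1sc(-c2ccc(Cl)cc2)c(-c2ccc(Cl)cc2)c1C(=O)N1CCCCC1=O` gives 4940 nM
- compound 2 `CC1CN(C(=O)c2c(N)sc(-c3ccc(Cl)cc3)c2-c2ccc(Cl)cc2)CCN1` gives 7210 nM
- compound 3 `Nc1sc(-c2ccc(Cl)cc2)c(-c2ccc(Cl)cc2)c1C(=O)NC1CCC1` gives 24800 nM

Compound 3 has the highest number of the three, which makes it the weakest inhibitor here. Compound 4 `Nc1sc(-c2ccc(Cl)cc2)c(-c2ccc(Cl)cc2)c1C(=O)NC1CCC(O)CC1` differs from it in one group 4-hydroxycyclohexyl in place of cyclobutyl on an amide-type nitrogen with 4-hydroxycyclohexyl in place of cyclobutyl on an amide-type nitrogen. For the measured compounds named here, two measured steps concern this part of the molecule: a 5.0-fold higher number from compound 1 to compound 3 (0.70 log units; beyond the scatter) and a 3.4-fold higher number from compound 2 to compound 3 (0.54 log units; beyond the scatter) are both modest. In each, the cyclobutylamino compound gave the higher number. Going by the values given here, no measured compound carries the 4-hydroxycyclohexyl group, so this evidence is indirect. The expected change in this assay is modest, namely a 2.1-fold lower number from compound 3 to compound 4 (0.32 log units; beyond the scatter) as estimated here. The estimate for compound 4 is 12000 nM with an expected range from 4000 nM to 35000 nM overall.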

Compound 4, half-maximal inhibitory concentration: 5670 nM
Estimate against measurement, compound 4: 2.1-fold (0.33 log units) above; low and high end bracket the measured number.
By their numbers in this assay, from the lowest: compounds 1, 4 and 2 (each within the scatter of the next); then compound 3.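

On the amide-type nitrogen, 4-hydroxycyclohexyl in place of cyclobutyl gives a 4.4-fold lower number from compound 3 to compound 4 (0.64 log units; beyond the scatter) in this assay, so the number responds to this group even when the nitrogen stays amide-type. The other two steps, a 1.3-fold lower number from compound 2 to compound 4 (0.10 log units; within the scatter) and a 1.1-fold higher number from compound 1 to compound 4 (0.06 log units; within the scatter), are within the scatter, so the high number of compound 3 is not shared by compound 4, although both carry an amino group of this type. Nothing measured here explains this step. As far as these compounds go, it remains open whether the hydroxyl or the larger ring matters, which a plain cyclohexyl group on this nitrogen could separate; a 4-aminocyclohexyl group would test another substituent there.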